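Ethynyl Amide to Branched Alkenyl Amide on a Shared Core

The source may hold more compounds than are shown below. What is called first, only, known or untested is meant among the compounds shown, and "the series" means these compounds.

Of the compounds shown here, three sharing one core have been measured in a functional assay on KYSE-450 cells (Homo sapiens) for inhibition, read by MTT assay, with a stated time of 48 h; on this read-out higher numbers stand for weaker inhibition and lower numbers for stronger inhibition. Compound 1 `COc1ccc(CNc2cc(OC)c(OC)c(OC)c2)cc1C` gives 73800 nM in this assay, and compound 3 `COc1cc(NCc2cccc(O)c2)cc(OC)c1OC` gives 71300 nM. Compound 2 `C#CC(=O)N(Cc1ccc(OC)c(O)c1)c1cc(OC)c(OC)c(OC)c1`, which carries an ethynylcarbonyl on the amide-type nitrogen, gives 570 nM; this is the lowest of the three numbers, and the gap to compound 3 as well as to compound 1 lies beyond the scatter. Going by the values given here, compound 2 therefore stands as the most potent of the three compounds measured so far.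

Compound 4 `COc1ccc(CN(C(=O)C=C(C)C)c2cc(OC)c(OC)c(OC)c2)cc1O` has not yet been tested. It differs from compound 2 in one place: 2-methylprop-1-en-1-yl in place of ethynyl on a carbonyl carbon. Among the compounds with values here, no pair of measured compounds differing in a single place is available, so the size of this step cannot be read from the data. The low number rests on compound 2 alone with its 570 nM; with its ethynyl gone, the number for compound 4 is expected to rise, though not back to the level of compound 1 or compound 3. The expected step is a 6.1-fold higher number from compound 2 to compound 4 (0.79 log units; beyond the scatter), a rise beyond the scatter. Compound 4 is estimated to give 3500 nM in this assay, within a range from 900 nM to 15000 nM.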

Compound 4, half-maximal inhibitory concentration: 280 nM
Estimate against measurement, compound 4: 13-fold (1.10 log units) above, outside the stated range (below it).
By their numbers in this assay, from the lowest: compound 4; then compound 2; then compounds 3 and 1 (each within the scatter of the next).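

In this assay, putting 2-methylprop-1-en-1-yl in place of ethynyl on a carbonyl carbon whose other neighbour is the amide-type nitrogen gives a 2.0-fold lower number from compound 2 to compound 4 (0.31 log units; beyond the scatter), a modest step but one beyond the scatter. Going by these compounds alone, this is the first comparison in the set that changes a single place, and it shows that the low number at this position does not depend on ethynyl: the triple bond gives way to a double bond, the group grows, and the number does not rise. Nothing available here accounts for the direction or the size of this step.

The step shows only that this one branched alkenyl group can stand in for ethynyl at this carbonyl carbon, and no steps can be read from compound 1 or compound 3, which differ from compound 2 and compound 4 in more than one place. From the compounds shown here alone, whether the lower number follows the double bond or the two methyl branches stays open, as does how an unbranched prop-1-en-1-yl, a saturated 2-methylpropyl or a longer chain ending in a dimethylamino group would read at the same carbonyl carbon.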